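This account rests on a few compounds, and the source may have more. Where it says the series, first, only, none or still open, it means among the compounds named here.

Measured so far:
Compound 1, `CC(C)CCOc1ccccc1C1CC(=O)c2ccccc2O1`: 47.6% in a functional assay on RAW264.7 cells (Mus musculus) for inhibition, read by immunoassay, with a stated time of 12 h, tested at 30 uM; a lower number here means less inhibition, a higher number more inhibition at the concentration tested (going by the name of the read-out)
Compound 2, `CCCCCOc1ccccc1C1CC(=O)c2ccccc2O1`: 41.3% in this assay

Among the measured compounds shown here, only two compounds have numbers. Compound 2 gives 41.3%, and compound 1 with 47.6% lies within the usual scatter of it, so the two cannot be put in an order. For the measured compounds named here, the one step between them, a number 6.3 percentage points lower from compound 1 to compound 2 (within the scatter), touches the same chain that is changed next and came out within the scatter.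

Compound 3, `COc1ccccc1C1CC(=O)c2ccccc2O1`, is still to be measured. It differs from compound 2 in one place: hydrogen in place of butyl on a saturated chain carbon bound to an oxygen on an aromatic ring. Going by the values given here, the single step seen so far only swapped the shape of the end of this chain and left the number essentially unchanged; nothing measured tells how a much shorter chain behaves. With so little to go on, a small drop is expected, but with a wide range: the estimated step of a number 7.3 percentage points lower from compound 2 to compound 3 (within the scatter) is not firmly beyond the scatter.

Compound 3 is therefore expected to give about 34%, between 10% and 58%.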

Compound 3, a percentage reported as inhibition, at one concentration (the size of the read-out at that concentration, not a potency): 37.3%
For compound 3 the middle estimate is 3.3 percentage points below the measured one, within the range that was stated.
By their numbers in this assay, from the lowest: compounds 3, 2 and 1 (each within the scatter of the next, the first and the last beyond it).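

Cutting the chain back to the methoxy group of compound 3 removes far more than the earlier swap at the chain's end, yet in this assay replacing butyl with hydrogen on the saturated chain carbon gives a number 4 percentage points lower from compound 2 to compound 3 (within the scatter) and so no order between the pentyloxy and methoxy compounds. Among the compounds shown here, replacing isobutyl in the same place gives a number 10.3 percentage points lower from compound 1 to compound 3 (beyond the scatter) as the only step so far beyond the scatter, and it is modest, so a shorter chain goes with a lower number in this one pair, while the pair of compound 2 and compound 3 does not show it. Most of the inhibition seen at this concentration therefore remains with only a methoxy group at this position, and no separate measurement is available to explain these numbers.

Still open, on these data alone, is how this position responds to something other than a plain saturated chain, such as a chain ending in an amine or a carboxylic acid, or a chain longer than pentyl. Open too, as far as these compounds go, is whether removing the oxygen substituent entirely, leaving a free hydroxyl group, would keep the inhibition.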